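A few compounds are considered here, and "the series" means these few. Any claim that something is new, unique, unknown or untested is made for them only; others in the source may bear on it.

Compound 2 `CC(C)Nc1nc(Nc2ccc(S(N)(=O)=O)cc2)ncc1/N=C/c1cccs1` carries a thiophen-2-yl group on a carbon with a double bond to nitrogen. In a functional assay on MCF7 cells (Homo sapiens) for antiproliferative activity, read by MTT assay (on this read-out higher numbers stand for weaker inhibition and lower numbers for stronger inhibition), compound 2 gives 50200 nM, the only actual number among these compounds. Compound 1 `CC(C)Nc1nc(Nc2ccc(S(N)(=O)=O)cc2)ncc1/N=C/c1ccccc1` differs only in having phenyl at that position. In this assay compound 1 reaches only a limit of the assay, > 100000 nM, which is the limit of > 100000 nM in this assay, at which 1 of the 2 values shown sits. For the measured compounds named here, the step of an at least 1.9-fold lower number from compound 1 to compound 2 (0.29 log units; that floor lies within the scatter) is thus the single measured comparison available. Compound 3 `CC(C)Nc1nc(Nc2ccc(S(N)(=O)=O)cc2)ncc1/N=C/c1ccc(C(F)(F)F)cc1` changes the same place: 4-(trifluoromethyl)phenyl in place of thiophen-2-yl on a carbon with a double bond to nitrogen. Because the measured step of an at least 1.9-fold lower number from compound 1 to compound 2 (0.29 log units; that floor lies within the scatter) shows the phenyl version sitting at the limit, going back to one six-membered aromatic ring of carbon only, now carrying trifluoromethyl, is expected to push the number up again by at least a similar amount, with a real chance that only a limit is reported. Compound 3 is therefore estimated at 100000 nM, within 40000 nM to 250000 nM, an expected step of a 2.0-fold higher number from compound 2 to compound 3 (0.30 log units; within the scatter).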

Compound 3, half-maximal inhibitory concentration: > 100000 nM
Compound 3 was reported as a limit; the forecaster's own chance of this, stated with the estimate: 50%; the middle value sits exactly at the limit.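

Swapping thiophen-2-yl for 4-(trifluoromethyl)phenyl on this carbon gives an at least 1.9-fold higher number from compound 2 to compound 3 (0.29 log units; that floor lies within the scatter), so the size of this change remains unknown and only a minimum can be stated. In this assay, compound 3 gives > 100000 nM, a limit of the assay and not a number, so a phenyl ring carrying trifluoromethyl now joins the unsubstituted phenyl ring of compound 1 in giving no actual number at this position. The step from compound 1 to compound 3 cannot be read, because both values are limits, and such values now make up most of this small set: the limit of > 100000 nM in this assay, at which 2 of the 3 values shown sit.

As far as these compounds go, it remains open whether a phenyl ring carrying an amine or a carboxylic acid in place of trifluoromethyl would give an actual number here. From the compounds shown here alone, it also remains open whether a furan-2-yl ring, with oxygen in place of the sulfur of thiophen-2-yl, would do so.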